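Bromo for Chloro, Measured Once and Now Expected Again

The source may report more compounds than this note shows. Statements on the series, on what has been measured and on what is new or still open speak of the compounds shown alone.

Of the compounds shown here, three built on one shared core have been measured in a functional assay on HT-29 cells (Homo sapiens) for antiproliferative activity, read by MTT assay, with a stated time of 72 h; a lower number here means a stronger inhibitor, a higher number a weaker inhibitor. Compound 1 `CNC(=O)c1cc(Oc2ccc(NC(=O)c3cc4cccnc4n(-c4ccc(Cl)cc4)c3=O)cc2)ccn1` gives 390 nM. Compound 2 `CNC(=O)c1cc(Oc2ccc(NC(=O)c3cc4cccnc4n(-c4ccc(Br)cc4)c3=O)cc2)ccn1` gives 1180 nM. Compound 3 `CCNC(=O)c1cc(Oc2ccc(NC(=O)c3cc4cccnc4n(-c4ccc(Cl)cc4)c3=O)cc2)ccn1` gives 330 nM, the lowest of the three numbers, though its step to compound 1 lies within the scatter.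

The two cores differ in one counted way, (methyl in place of hydrogen on a saturated chain carbon bound to an amide-type nitrogen), and the step was a 1.2-fold lower number from compound 1 to compound 3 (0.07 log units; within the scatter). The other difference already measured is bromo in place of chloro on an aromatic carbon, where the step was a 3.0-fold higher number from compound 1 to compound 2 (0.48 log units; beyond the scatter), a modest but real shift.

Compound 4 `CCNC(=O)c1cc(Oc2ccc(NC(=O)c3cc4cccnc4n(-c4ccc(Br)cc4)c3=O)cc2)ccn1` has not yet been measured in this assay. It differs from compound 3 by bromo in place of chloro on an aromatic carbon, the same change that carried compound 1 to compound 2, at a place described in the same words; among the compounds shown this change occurs twice in all.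

Among the measured compounds shown here, a step of similar size is expected because a 3.0-fold higher number from compound 1 to compound 2 (0.48 log units; beyond the scatter) is the only precedent, so for compound 4 the expected step is a 3.0-fold higher number from compound 3 to compound 4 (0.48 log units; beyond the scatter). The estimate for compound 4 is 1000 nM, expected to fall between 500 nM and 2000 nM.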

Compound 4, half-maximal inhibitory concentration: 1160 nM
The estimate for compound 4 lay 1.2-fold (0.06 log units) below the measured number, within the range that was stated.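

In this assay, bromo in place of chloro gave a 3.5-fold higher number from compound 3 to compound 4 (0.55 log units; beyond the scatter), which matches the step seen earlier on the core of compound 1: the same change on two cores in this assay, a 3.0-fold higher number (0.48 log units; beyond the scatter) from compound 1 to compound 2 and a 3.5-fold higher number (0.55 log units; beyond the scatter) from compound 3 to compound 4, 1.2-fold (0.07 log units) apart, within the scatter of two such steps Methyl in place of hydrogen on the chain gave a 1.0-fold lower number from compound 2 to compound 4 (0.01 log units; within the scatter), and this step also agrees with its earlier counterpart: the same change on two cores in this assay, a 1.2-fold lower number (0.07 log units; within the scatter) from compound 1 to compound 3 and a 1.0-fold lower number (0.01 log units; within the scatter) from compound 2 to compound 4, 1.2-fold (0.07 log units) apart, within the scatter of two such steps Across these four compounds, each change therefore carried from one core to the other with its size intact, but the two cores differ in only one place, so this does not show that either change would carry to a core differing elsewhere, and it does not explain why bromo gives the higher number.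

The compounds shown leave open how fluoro, iodo or methoxy in place of chloro would read, and whether a propyl or longer chain on the amide nitrogen would stay level with the chains shown. They also leave open whether the bromo step holds on any other cell line.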